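The source may hold more compounds than are shown below. What is called first, only, known or untested is meant among the compounds shown, and "the series" means these compounds.

Compound 1 `COc1cccc(C(=O)NCCNC(=O)[C@H](CC(=O)NC(C)(C)C)NS(=O)(=O)c2ccc(C)cc2)c1` is the reference point of the series. In an ADME assay on Karpas-1106P cells (Homo sapiens) for cytotoxicity (on this read-out lower numbers stand for an effect already at smaller amounts and higher numbers for an effect only at larger amounts of compound), compound 1 gives > 11100 nM, which is a limit of the assay and not a number. Compound 2 `Cc1ccc(S(=O)(=O)N[C@@H](CC(=O)NC(C)(C)C)C(=O)NCCNC(=O)c2cccc(C#N)c2)cc1` carries cyano in place of methoxy on an aromatic carbon. In this assay compound 2 gives > 11100 nM, also a limit. The step that the two limits leave unreadable from compound 1 to compound 2 is therefore unreadable; both values rest at the limit of > 11100 nM in this assay, at which 2 of the 2 values shown sit. Compound 3 `Cc1ccc(S(=O)(=O)N[C@@H](CC(=O)NC(C)(C)C)C(=O)NCCNS(=O)(=O)c2ccccc2)cc1` differs from compound 1 by phenylsulfonyl in place of (3-methoxyphenyl)carbonyl on an amine nitrogen. Among the measured compounds shown here, no measured step covers this change, and the single step yields no size, so the expectation for compound 3 rests only on where compound 1 stands, at the limit. The step that the limit leaves unreadable from compound 1 to compound 3 is expected to be none beyond the scatter. Compound 3 is estimated at 20000 nM, between 8000 nM and 50000 nM, and most likely to be reported again only as a limit.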

Compound 3, half-maximal effective concentration: > 11100 nM
Compound 3: only a limit was reported (the forecaster's own chance of this, stated with the estimate: 80%); the middle value lies beyond the limit too.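

The steps from compound 1 and from compound 2 to compound 3 cannot be read, as all three values are limits of the assay: the limit of > 11100 nM in this assay, at which 3 of the 3 values shown sit.

The compounds shown leave open whether any change to the shared core gives a measurable value, and how large any such step would be.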